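Methylating the Ring Nitrogen of Compound 2

The compounds below may be only part of what the source reports. "The series", "measured", "known", "first", "only" and "open" are said of these compounds alone.

Compound 1, `OC(c1nc2cc(Cl)c(Cl)cc2[nH]1)C(F)(F)F`: 132%
Compound 2, `CC(C)(O)c1nc2cc(Cl)c(Cl)cc2[nH]1`: 100%

In an in vivo ADME assay on the whole organism (strain Sprague-Dawley) for pharmacokinetics, with Rattus norvegicus as the target (on this read-out higher numbers stand for higher oral bioavailability and lower numbers for lower oral bioavailability), compound 2 gives 100%, the lowest of the two numbers shown; compound 1 in this assay gives 132%, a value that lies higher by a gap beyond the scatter. Compound 3, `Cn1c(C(C)(C)O)nc2cc(Cl)c(Cl)cc21`, differs from compound 2 by methyl in place of hydrogen on an aromatic nitrogen. Within the data shown here, no measured pair shows this change, so the size of the step is unknown; a step close to the scatter, in either direction, is expected. For compound 3 the expected step is a number 5 percentage points lower from compound 2 to compound 3 (within the scatter). Compound 3 is therefore estimated at 95%, in a range from 60% to 130%.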

Compound 3, oral bioavailability: 100%
Beside the measured number, compound 3's estimate is 5 percentage points below it, within the range that was stated.
By their numbers in this assay, from the lowest: compounds 2 and 3 (each within the scatter of the next); then compound 1.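

In this assay, placing methyl in place of hydrogen on the aromatic nitrogen gives no change at the digits printed from compound 2 to compound 3 (within the scatter). In this pair, then, the hydrogen on that ring nitrogen, next to the ring atom that bears a 1-hydroxy-1-methylethyl group, is not needed to hold this read-out at the level of compound 2. Nothing measured here gives a reason for this outcome.

From the compounds shown here alone, whether a longer chain such as propyl or a benzyl group on this nitrogen would fit the same picture stays open. So does whether methyl would give a similar step on the nitrogen of compound 1.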